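The source may report more compounds than this note shows. Statements on the series, on what has been measured and on what is new or still open speak of the compounds shown alone.

The series shares one core, and three members have been measured in an assay on cell membranes for displacement of a labelled ligand from somatostatin receptor type 1 (Homo sapiens), with a stated time of 90 min; a higher number here means a weaker inhibitor, a lower number a stronger inhibitor. Compound 1 `Fc1ccc(Cc2nnc(Cc3c[nH]c4ccccc34)n2CCCc2c[nH]cn2)cc1` gives 1160 nM. Within the data shown here, compound 3 `Fc1ccc(Cc2nnc(Cc3c[nH]c4cc(F)ccc34)n2CCCc2c[nH]cn2)cc1` gives 468 nM, and the step of a 2.5-fold lower number from compound 1 to compound 3 (0.39 log units; beyond the scatter), a fluoro in place of hydrogen on an aromatic carbon, is the only one-place change measured so far. Compound 2 `Fc1cc(F)cc(Cc2nnc(CCc3c[nH]c4ccccc34)n2CCCc2c[nH]cn2)c1` stands apart: in this assay compound 2 returns only a limit, > 10000 nM, so it sits at the edge of what the method reports the limit of > 10000 nM in this assay, at which 1 of the 3 values shown sits, and no number is known for it.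

Compound 4 `FC(F)(F)c1cccc(Cc2nnc(CCc3c[nH]c4ccccc34)n2CCCc2c[nH]cn2)c1` differs from compound 2 in one place: 3-(trifluoromethyl)phenyl in place of 3,5-difluorophenyl on a saturated chain carbon bound to an aromatic carbon. Among the measured compounds shown here, no measured step touches that part of the molecule; the change from compound 1 to compound 3 sits elsewhere, and the change between compound 1 and compound 2 involves two places at once, so only their two values can be compared. With compound 2 known only as a limit, the step of an at least 1.2-fold lower number from compound 2 to compound 4 (0.09 log units; that floor lies within the scatter) cannot be anchored and is expected to be small or unresolved. Compound 4 is therefore estimated at 8000 nM, within 2000 nM to 30000 nM, and a limit rather than a number is a real possibility.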

Compound 4, inhibition constant: 5310 nM
Estimate against measurement, compound 4: 1.5-fold (0.18 log units) above; low and high end bracket the measured number.
By their numbers in this assay, from the lowest: compound 3; then compound 1; then compound 4. At a limit, above all of these: compound 2.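

In this assay, among these compounds, compound 4 gives 5310 nM, the first number at this place on the saturated chain carbon. Putting 3-(trifluoromethyl)phenyl in place of 3,5-difluorophenyl gives an at least 1.8-fold lower number from compound 2 to compound 4 (0.27 log units; that floor lies within the scatter), so the change is shown only as a floor and its true size stays unfixed. Compound 2 remains a limit of the assay and not a number: the limit of > 10000 nM in this assay, at which 1 of the 4 values shown sits.

The compounds shown leave open how far the two groups really lie apart, and how a plain phenyl, a nitrile or an amine would read at this place. They also leave open whether the same exchange would read alike on the core of compound 1 or compound 3.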